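A few compounds are considered here, and "the series" means these few. Any claim that something is new, unique, unknown or untested is made for them only; others in the source may bear on it.

Two compounds of a shared core have been examined here. Compound 1 (`Cc1cccc(N2CCN(C(=O)C(C)N3C(=O)CC(C)C3=O)CC2)c1`) is known only by its structure; its entry in a functional assay on the whole organism (strain Swiss) with Mus musculus as the target, with a stated time of 0.25 h (a lower number here means that less compound is needed, a higher number that more compound is needed for the effect), for compound 1 reads "not determined" (no result reported), as no result was reported for it. Within the data shown here, compound 2 (`CC1CC(=O)N(C(C)C(=O)N2CCN(c3cccc(Cl)c3)CC2)C1=O`) is the one with a number: in this assay compound 2 gives 114 mg/kg, and as the only figure available it serves as the sole anchor for anything further.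

Compound 3 (`CC1CC(=O)N(C(C)C(=O)N2CCN(c3cccc(C(F)(F)F)c3)CC2)C1=O`) has not yet been tested. It differs from compound 2 in one place: trifluoromethyl in place of chloro on an aromatic carbon of a six-membered aromatic ring of carbon only, meta to a large group. Among the measured compounds shown here, no measured pair shows how such a swap plays out in this assay. With nothing to point either way, the expectation for the step from compound 2 to compound 3 is a 1.1-fold higher number from compound 2 to compound 3 (0.02 log units; within the scatter), a change not beyond the usual scatter. Compound 3 is therefore estimated at 120 mg/kg, with a range of 50 mg/kg to 300 mg/kg.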

Compound 3, dose for half-maximal effect: 65.7 mg/kg
Beside the measured number, compound 3's estimate is 1.8-fold (0.26 log units) above it; measured number inside the range.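

Among these compounds, this is the first measured pair for this change on an aromatic carbon of the ring, and in this assay trifluoromethyl in place of chloro gives a 1.7-fold lower number from compound 2 to compound 3 (0.24 log units; within the scatter). Although the entering group has 4 heavy atoms and the leaving group has 1, this step does not separate the two groups, so at this position the exchange leaves no readable effect on the dose needed. Nothing measured here offers an explanation for the result.

The compounds shown leave open how a group of a different kind, such as an amine or a carboxylic acid, would behave at this position. They also leave open whether trifluoromethyl and chloro would remain indistinguishable on another carbon of the ring.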